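The compounds below may be only part of what the source reports. "The series", "measured", "known", "first", "only" and "open" are said of these compounds alone.

Measured so far:
- compound 1 `O=C(Nc1ccc(I)cc1)c1cncc(N2CC3CC(C2)N3)c1`: 0.366 nM
- compound 2 `O=C(Nc1ccc(F)cc1)c1cncc(N2CC3CC(C2)N3)c1`: 0.01 nM

In an assay on membranes from Cerebral cortex for displacement of a labelled ligand from Neuronal acetylcholine receptor; alpha4/beta2 (Rattus norvegicus) (on this read-out higher numbers stand for weaker inhibition and lower numbers for stronger inhibition), compound 1 stands at the higher of the two numbers; compound 2 lies well under it, the difference being a 37-fold lower number from compound 1 to compound 2 (1.56 log units; beyond the scatter).

Compound 3 `COc1cccc(NC(=O)c2cncc(N3CC4CC(C3)N4)c2)c1` is not yet measured. Against compound 1 the difference is 3-methoxyphenyl in place of 4-iodophenyl on an amide-type nitrogen. For the measured compounds named here, the one measured step, from compound 1 to compound 2, swaps one halogen for another at the same place on the ring and does not move the group, so it bears only loosely on this change; it shows that the shared core tolerates a change of the ring substituent with a large shift, a 37-fold lower number from compound 1 to compound 2 (1.56 log units; beyond the scatter), towards a lower number. With a different group at a different place, the direction is uncertain; a moderate move towards a lower number is expected, with a broad range.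

Compound 3 is therefore estimated at 0.15 nM (range 0.02 nM to 1.2 nM), an expected step of a 2.4-fold lower number from compound 1 to compound 3 (0.39 log units; beyond the scatter).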

Compound 3, inhibition constant: 0.56 nM
Beside the measured number, compound 3's estimate is 3.7-fold (0.57 log units) below it; the range from low to high includes it.
By their numbers in this assay, from the lowest: compound 2; then compounds 1 and 3 (each within the scatter of the next).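

In this assay the exchange of 4-iodophenyl for 3-methoxyphenyl on the amide-type nitrogen (a 1.5-fold higher number from compound 1 to compound 3 (0.18 log units; within the scatter)) stays within the scatter, even though both the group and its place on the ring differ. The same 3-methoxyphenyl set against 4-fluorophenyl gives a large step (a 56-fold higher number from compound 2 to compound 3 (1.75 log units; beyond the scatter)), so among these three compounds the low number belongs to compound 2 alone, and a group on this ring does not by itself bring it. No supporting measurement bears on why these steps differ in size.

From the compounds shown here alone, compound 3 changes both the group and its place, so the separate contribution of each remains open, and 4-methoxyphenyl would bear directly on this. Also open, going by these compounds, is how the position responds to an amine or a carboxylic acid on the ring.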